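Replacing a naphthalene sulfonyl with a trifluoromethylphenyl sulfonyl

A few compounds are considered here, and "the series" means these few. Any claim that something is new, unique, unknown or untested is made for them only; others in the source may bear on it.

The measured compounds and their values in a functional assay on CHO cells for antagonist activity at 5-hydroxytryptamine receptor 6 (Homo sapiens), read by FLIPR (a lower number here means a stronger inhibitor, a higher number a weaker inhibitor), are:
compound 1 `COc1ccc(S(=O)(=O)N2CC(C(=O)N3CC(N)C3)c3ccccc32)c2ccccc12` gives 158 nM
compound 2 `CCN(CC)CCNC(=O)C1CN(S(=O)(=O)c2ccc(OC)c3ccccc23)c2ccccc21` gives 20 nM
compound 3 `CN1CCC(N(C)C(=O)C2CN(S(=O)(=O)c3cccc4c(Cl)cccc34)c3ccccc32)CC1` gives 5.01 nM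

Compound 3 stands lowest of the three numbers in this assay, beyond the scatter from both compound 2 and compound 1. The unmeasured compound 4 `CN1CCC(N(C)C(=O)C2CN(S(=O)(=O)c3ccc(C(F)(F)F)cc3)c3ccccc32)CC1` differs from compound 3 at one place: 4-(trifluoromethyl)phenyl in place of 5-chloronaphthalen-1-yl on a sulfonyl sulfur. For the measured compounds named here, the one measured step, a 7.9-fold lower number from compound 1 to compound 2 (0.90 log units; beyond the scatter), is at the carbonyl carbon and not at the sulfonyl sulfur, so it does not bear on this change; no measured pair varies the aryl group on the sulfonyl sulfur, and compounds 1 and 2 differ from compound 3 at more than one place. Without a guiding step, the expectation for compound 4 rests on the change alone, and a modest step towards a higher number is estimated, a 4.0-fold higher number from compound 3 to compound 4 (0.60 log units; beyond the scatter). Compound 4 is therefore expected to give about 20 nM, with a range from 5 nM to 80 nM.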

Compound 4, inhibition constant: 25.1 nM
Estimate against measurement, compound 4: 1.3-fold (0.10 log units) below, and the stated range covers the measured number.
By their numbers in this assay, from the lowest: compound 3; then compounds 2 and 4 (each within the scatter of the next); then compound 1.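

For the compounds shown here, compound 4 gives the first measured step at the sulfonyl sulfur with the rest of the molecule held fixed: in this assay, 4-(trifluoromethyl)phenyl in place of 5-chloronaphthalen-1-yl gives a 5.0-fold higher number from compound 3 to compound 4 (0.70 log units; beyond the scatter). The position therefore responds to this change beyond the scatter, but the step is modest, and with one six-membered aromatic ring in place of two, compound 4 still gives 25.1 nM. No measurement shown here accounts for the size of this step.

The compounds shown do not separate the loss of the second aromatic ring from the exchange of chlorine for trifluoromethyl, and they do not place a plain phenyl or a chlorophenyl group on the sulfonyl sulfur. Nor do they show whether the step would hold with (2-(diethylamino)ethyl)amino on the carbonyl carbon.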